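The source may hold more compounds than are shown below. What is called first, only, known or untested is meant among the compounds shown, and "the series" means these compounds.

Measured in a functional assay on SW-620 cells (Homo sapiens) for cytotoxicity, read by MTT assay, with stated times of 4 h and 72 h, tested at 2 uM; on this read-out higher numbers stand for weaker inhibition and lower numbers for stronger inhibition:
Compound 1 `Cc1cc(Nc2ccc(C(=O)/C=C/c3ccccc3)cc2)n2nc(SCc3nc4ccccc4[nH]3)nc2n1`: 130 nM
Compound 2 `Cc1cc(Nc2ccc(C(=O)/C=C/c3ccccc3F)cc2)n2nc(SCc3nc4ccccc4[nH]3)nc2n1`: 250 nM

Compound 2, at 250 nM, cannot be told apart from compound 1, since a 1.9-fold higher number from compound 1 to compound 2 (0.28 log units; within the scatter) stays within the scatter. Compound 3 `Cc1cc(Nc2ccc(C(=O)/C=C/c3ccc(Br)cc3)cc2)n2nc(SCc3nc4ccccc4[nH]3)nc2n1` carries 4-bromophenyl in place of 2-fluorophenyl on a double-bonded chain carbon bound to a double-bonded chain carbon. Among the compounds with values here, the only measured step bearing on this swaps fluoro for hydrogen on an aromatic carbon, and no bromine compound has a number yet. In this assay, the expected change, a 1.3-fold lower number from compound 2 to compound 3 (0.10 log units; within the scatter), is therefore none beyond the scatter, with no clear direction. Compound 3 is estimated at 200 nM, with an expected range of 80 nM to 500 nM.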

Compound 3, half-maximal inhibitory concentration: 290 nM
Beside the measured number, compound 3's estimate is 1.5-fold (0.16 log units) below it, within the range that was stated.
By their numbers in this assay, from the lowest: compounds 1, 2 and 3 (each within the scatter of the next, the first and the last beyond it).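

Within the data shown here, the step to 4-bromophenyl gives a 2.2-fold higher number from compound 1 to compound 3 (0.35 log units; beyond the scatter) in this assay, the first step to pass the scatter, though only modestly. Moving from 2-fluorophenyl to 4-bromophenyl gives a 1.2-fold higher number from compound 2 to compound 3 (0.06 log units; within the scatter), so compound 2 and compound 3 cannot be told apart. Nothing measured here explains either step. Because that swap changes both the halogen and its place on the ring, the effect of each remains unresolved; 4-fluorophenyl and 2-bromophenyl would separate them. From the compounds shown here alone, how a non-halogen group, such as an amine, would read also remains open.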